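The source may report more compounds than this note shows. Statements on the series, on what has been measured and on what is new or still open speak of the compounds shown alone.

The measured compounds:

compound 1, `COc1ccc(-c2nc3cc(C(C)=O)ccc3[nH]2)c(OC)c1`: > 100000 nM
compound 2, `COc1cc(OC)cc(-c2nc3cc(C(F)(F)F)ccc3[nH]2)c1`: > 100000 nM
compound 3, `COc1ccc(-c2nc3cc(C(C)=O)ccc3[nH]2)c(OC)c1OC`: > 100000 nM

In an ADME assay on MDBK cells (Bos taurus) for cytotoxicity, read by MTT assay, with a stated time of 96 h (a lower number here means that less compound is tolerated, a higher number that more compound is tolerated), compound 1 gives > 100000 nM, which is a limit of the assay and not a number. Compound 2 gives > 100000 nM, again a limit. Compound 3 gives > 100000 nM, also a limit. The step that the two limits leave unreadable from compound 1 to compound 3 comes from the change (methoxy in place of hydrogen on an aromatic carbon). The difference between the cores of compound 1 and compound 2 is not broken down here. Compound 4, `COc1cc(-c2nc3cc(C(F)(F)F)ccc3[nH]2)cc(OC)c1OC`, is not yet measured; it arises from compound 2 by the change (methoxy in place of hydrogen on an aromatic carbon), the same kind of change as that from compound 1 to compound 3, though the place differs: meta to a large group in one, para to a large group in the other. Given (the limit of > 100000 nM in this assay, at which 3 of the 3 values shown sit), the step that the limit leaves unreadable from compound 2 to compound 4 is expected to be small, and compound 4 is estimated at 150000 nM, between 60000 nM and 400000 nM.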

Compound 4, half-maximal cytotoxic concentration: 18000 nM
Compound 4: the middle estimate sits 8.3-fold (0.92 log units) above what was measured; measured number outside the range, below it.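

In this assay the methoxy in place of hydrogen, para to a large group on the core of compound 2, gives an at least 5.5-fold lower number from compound 2 to compound 4 (0.74 log units; beyond the scatter) on that core. Compound 3 gives > 100000 nM, which is a limit of the assay and not a number. On these data alone, whether the lower number carries over to the core of compound 1 therefore stays unknown, because the step from compound 1 to compound 3 cannot be read and the methoxy stands at a different place there: the limit of > 100000 nM in this assay, at which 3 of the 4 values shown sit.

The compounds shown leave open whether an ethoxy or an amine at the same place would also lower the number. They also leave open what a carboxylic acid in place of the trifluoromethyl of compound 4 would give.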